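This account rests on a few compounds, and the source may have more. Where it says the series, first, only, none or still open, it means among the compounds named here.

Going by the values given here, in a physicochemical assay for permeability, using PAMPA, at pH 7.4 (a higher number here means that the compound crosses the layer faster, a lower number that the compound crosses the layer more slowly), compound 3 `NCCS(=O)(=O)NC(=O)c1ccc(Nc2nc(NC3(c4ccc(Cl)cc4)CC3)nc(OCC(F)(F)F)n2)cc1` gives 153 nm/s, the highest of the three numbers measured so far; compound 2 `CC(C)(C)OC(=O)NCCS(=O)(=O)NC(=O)c1ccc(Nc2nc(NC3(c4ccc(Cl)cc4)CC3)nc(OCC(F)(F)F)n2)cc1` gives 111 nm/s, within the scatter of it, while compound 1 `CC(C)S(=O)(=O)NC(=O)c1ccc(Nc2nc(NC3(c4ccc(Cl)cc4)CC3)nc(OCC(F)(F)F)n2)cc1` gives 31 nm/s. Compound 4 `Cc1ccccc1S(=O)(=O)NC(=O)c1ccc(Nc2nc(NC3(c4ccc(Cl)cc4)CC3)nc(OCC(F)(F)F)n2)cc1` differs from compound 3 by 2-methylphenyl in place of 2-aminoethyl on a sulfonyl sulfur. Among the compounds with values here, no measured step covers an aromatic group on this sulfur; the steps that bear on it are a 4.9-fold higher number from compound 1 to compound 3 (0.69 log units; beyond the scatter) and a 3.6-fold higher number from compound 1 to compound 2 (0.55 log units; beyond the scatter). Because compound 1 gives 31 nm/s with an isopropyl that carries no donor or acceptor, compound 4 is expected to fall back toward it, a modest step down, a 3.4-fold lower number from compound 3 to compound 4 (0.53 log units; beyond the scatter). Compound 4 is estimated at 45 nm/s, within 15 nm/s to 130 nm/s.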

Compound 4, apparent permeability: 265 nm/s
Beside the measured number, compound 4's estimate is 5.9-fold (0.77 log units) below it; measured number above the stated range.
By their numbers in this assay, from the lowest: compound 1; then compounds 2, 3 and 4 (each within the scatter of the next, the first and the last beyond it).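

In this assay, going by these compounds alone, an aromatic group on the sulfonyl sulfur appears for the first time, and 2-methylphenyl, with 0 hydrogen-bond donors and 0 hydrogen-bond acceptors, stands level with 2-aminoethyl (a 1.7-fold higher number from compound 3 to compound 4 (0.24 log units; within the scatter)). It stands clear of the other two groups (a 2.4-fold higher number from compound 2 to compound 4 (0.38 log units; beyond the scatter); an 8.5-fold higher number from compound 1 to compound 4 (0.93 log units; beyond the scatter)), so among these compounds a donor on this group is not needed for the higher numbers. Nothing at hand accounts for these differences. As far as these compounds go, it remains open whether the methyl of 2-methylphenyl matters, as an unsubstituted phenyl would show, and how a carboxylic acid or a longer chain on this sulfur would read.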